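A Second Chain Double Bond in a Kallikrein-7 Series

The compounds below may be only part of what the source reports. "The series", "measured", "known", "first", "only" and "open" are said of these compounds alone.

Compound 1 `CCCCCCCCCCC/C(O)=C1/C(=O)[C@H](Cc2ccccc2)N(C(=O)OC(C)(C)C)C1=O` gives 2300 nM
Compound 2 `CCCCCCCCCCCCC/C(O)=C1/C(=O)[C@H](Cc2ccccc2)N(C(=O)OC(C)(C)C)C1=O` gives 1700 nM
Compound 3 `CCCCCCCC/C=C\CCCCCCC/C(O)=C1/C(=O)[C@H](Cc2ccccc2)N(C(=O)OC(C)(C)C)C1=O` gives 2500 nM

In an assay on isolated protein for inhibition of kallikrein-7 (Homo sapiens) (on this read-out lower numbers stand for stronger inhibition and higher numbers for weaker inhibition), compound 3 shows the highest of the three numbers, yet its gaps to the other two are within the scatter, so the three compounds are not distinguishable. Compound 4 `CCCCC/C=C\C/C=C\CCCCCCC/C(O)=C1/C(=O)[C@H](Cc2ccccc2)N(C(=O)OC(C)(C)C)C1=O` differs from compound 3 by hept-1-en-1-yl in place of heptyl on a saturated chain carbon bound to a double-bonded chain carbon, which puts a second double bond into the chain. The steps that brought the first chain double bond in, a 1.1-fold higher number from compound 1 to compound 3 (0.04 log units; within the scatter) and a 1.5-fold higher number from compound 2 to compound 3 (0.17 log units; within the scatter), both stayed within the scatter, as did the lengthening a 1.4-fold lower number from compound 1 to compound 2 (0.13 log units; within the scatter). In this assay no step beyond the scatter is therefore expected, and the expected step is no change at the digits printed from compound 3 to compound 4 (within the scatter). Compound 4 is estimated at 2500 nM, with a range from 1200 nM to 5500 nM.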

Compound 4, half-maximal inhibitory concentration: 14000 nM
Compound 4: the middle estimate sits 5.6-fold (0.75 log units) below what was measured; the whole stated range lies below it.
By their numbers in this assay, from the lowest: compounds 2, 1 and 3 (each within the scatter of the next); then compound 4.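

Where the lengthening and the first chain double bond moved nothing beyond the scatter in this assay, this second double bond does: hept-1-en-1-yl in place of heptyl gives a 5.6-fold higher number from compound 3 to compound 4 (0.75 log units; beyond the scatter), the first clear loss of inhibition in the series. The saturated chains show the same loss, with an 8.2-fold higher number from compound 2 to compound 4 (0.92 log units; beyond the scatter) and a 6.1-fold higher number from compound 1 to compound 4 (0.78 log units; beyond the scatter), so this position does respond to the chain's make-up. No evidence at hand accounts for the loss. Still open, as far as these compounds go, is whether the loss follows the number of double bonds or this particular place, and what a third chain double bond or a chain carrying a carboxylic acid would do.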